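Working notes: from compound 1 to compound 3

The source may hold more compounds than are shown below. What is called first, only, known or untested is meant among the compounds shown, and "the series" means these compounds.

Measured in a functional assay on HCT-116 cells (Homo sapiens) for antiproliferative activity, read by MTT assay, with a stated time of 72 h; a higher number here means a weaker inhibitor, a lower number a stronger inhibitor:
- compound 1 `N=C(NC(=N)NC1CCCC1)Nc1ccc(C(F)(F)F)cc1`: 3800 nM
- compound 2 `CC(C)NC(=N)NC(=N)Nc1ccc(F)c(F)c1`: > 50000 nM, a limit of the assay

So far, compound 1 at 3800 nM holds the only numerical value in the series. The entry for compound 2, > 50000 nM, is a limit and not a number.

The next compound is compound 3 `CCN(CC)C(=N)NC(=N)Nc1ccc(C(F)(F)F)cc1`, with the change diethylamino in place of cyclopentylamino on a carbon with a double bond to nitrogen. The rest of the core of compound 1 stays as it is. Among the measured compounds shown here, no measured pair isolates a change of this kind, so the expectation is only a loose one. In this assay, a modest weakening is expected, not much beyond the scatter. The expected step is a 1.8-fold higher number from compound 1 to compound 3 (0.27 log units; within the scatter). Compound 3 is estimated at 7000 nM, with an expected range of 2500 nM to 25000 nM.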

Compound 3, half-maximal inhibitory concentration: 4300 nM
Estimate against measurement, compound 3: 1.6-fold (0.21 log units) above; measured number inside the range.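

In this assay the series gains its first readable step at this place, on a carbon with a double bond to nitrogen: a 1.1-fold higher number from compound 1 to compound 3 (0.05 log units; within the scatter). Diethylamino, with no ring and 0 hydrogen-bond donors, stands here in place of cyclopentylamino, with its five-membered non-aromatic ring of carbon and 1 hydrogen-bond donor, and the read-out does not separate the two groups. No measurement in hand bears on this step or offers an account of it.

Going by these compounds, whether morpholine or dipropylamino at the same place would leave the number in the same range remains open. Among the compounds shown here, compound 2 has > 50000 nM as its entry, which is a limit and not a number, and it differs from compound 1 and compound 3 in more than one place, so no step to it can be read.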